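Swapping the Small Azole on the Piperazine Arm

This account rests on a few compounds, and the source may have more. Where it says the series, first, only, none or still open, it means among the compounds named here.

Two compounds share one core, differing only in the small aromatic ring attached to a saturated chain carbon bound to an amine nitrogen in a ring. Compound 1 `Cn1cnc(CN2CCN(c3cccc4[nH]c(-c5ccc(C(C)(C)C)cc5)nc34)CC2)c1` carries a 1-methyl-1H-imidazol-4-yl there and gives 98 nM in an assay on isolated protein for displacement of a labelled ligand from Gonadotropin-releasing hormone receptor (Rattus norvegicus); a lower number here means a stronger inhibitor, a higher number a weaker inhibitor. Among the measured compounds shown here, compound 2 `CCc1cc(CN2CCN(c3cccc4[nH]c(-c5ccc(C(C)(C)C)cc5)nc34)CC2)nn1C` carries a 5-ethyl-1-methyl-1H-pyrazol-3-yl and gives 350 nM; this is the highest number of the two, and the step of a 3.6-fold higher number from compound 1 to compound 2 (0.55 log units; beyond the scatter) is the only measured change available. Compound 3 `CCCCn1cnc(CN2CCN(c3cccc4[nH]c(-c5ccc(C(C)(C)C)cc5)nc34)CC2)c1C` has not yet been tested; it differs from compound 2 by 1-butyl-5-methyl-1H-imidazol-4-yl in place of 5-ethyl-1-methyl-1H-pyrazol-3-yl on a saturated chain carbon bound to an amine nitrogen in a ring, so it returns to the imidazol-4-yl arrangement of compound 1 while adding a butyl and a methyl on that ring. For the measured compounds named here, the one measured step suggests the pyrazole brought a weaker number, so going back to an imidazole is expected to move in the opposite direction, with the extra chain an unknown. Compound 3 is therefore expected to give roughly 130 nM, within 40 nM to 450 nM, an estimated step of a 2.7-fold lower number from compound 2 to compound 3 (0.43 log units; beyond the scatter).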

Compound 3, half-maximal inhibitory concentration: 49 nM
Compound 3: the middle estimate sits 2.7-fold (0.42 log units) above what was measured, within the range that was stated.
By their numbers in this assay, from the lowest: compounds 3 and 1 (each within the scatter of the next); then compound 2.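

In this assay, putting 1-butyl-5-methyl-1H-imidazol-4-yl in place of 5-ethyl-1-methyl-1H-pyrazol-3-yl on the saturated chain carbon gives a clear change in the favourable direction (a 7.1-fold lower number from compound 2 to compound 3 (0.85 log units; beyond the scatter)), so the weaker number of compound 2 is not a general result of substituting this small ring. The comparison with the smaller imidazole is the more telling one: the step is a 2.0-fold lower number from compound 1 to compound 3 (0.30 log units; within the scatter), so no difference can be claimed, and 1-butyl-5-methyl-1H-imidazol-4-yl is accepted here with no measurable loss relative to 1-methyl-1H-imidazol-4-yl. No measurement in hand explains either step.

Going by these compounds, the butyl and the added methyl enter together, and compound 2 differs from compound 3 in ring type as well as in its substituents, so the separate contribution of each of these changes remains unknown. On these data alone, it also remains open whether this position would accept a longer chain such as hexyl, or a butyl chain ending in an amine or a carboxylic acid, with a number that stays in the range of compound 1 and compound 3.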